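Predicting a Methyl-for-Chloro Swap on an Indole Benzyl Arm

This account rests on a few compounds, and the source may have more. Where it says the series, first, only, none or still open, it means among the compounds named here.

This account concerns four urea-linked thiazole hydrazones tested in a functional assay on A549 cells (Homo sapiens) for cytotoxicity, read by MTT assay, with a stated time of 72 h; a higher number here means a weaker inhibitor, a lower number a stronger inhibitor. Compound 1 `CCN(CC)Cc1ccc2nc(NC(=O)N/N=C/c3cn(Cc4ccc(C)cc4)c4ccccc34)sc2c1` gives 1510 nM in this assay. Compound 2 `CCN(CC)Cc1ccc2nc(NC(=O)N/N=C/c3cn(Cc4ccc(Cl)cc4)c4ccccc34)sc2c1` gives 2940 nM in this assay. Compound 3 `CN(C)Cc1ccc2nc(NC(=O)N/N=C/c3cn(Cc4ccc(Cl)cc4)c4ccccc34)sc2c1` gives 840 nM in this assay. Compound 4 `Cc1ccc(Cn2cc(/C=N/NC(=O)Nc3nc4ccc(CN(C)C)cc4s3)c3ccccc32)cc1` has not yet been measured in this assay.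

Two measured steps frame the question. From compound 2 to compound 1 the change is methyl in place of chloro on an aromatic carbon, and this assay records a 1.9-fold lower number from compound 2 to compound 1 (0.29 log units; within the scatter). The two cores of compound 2 and compound 3 differ by dimethylamino in place of diethylamino on a saturated chain carbon bound to an aromatic carbon, and this assay records a 3.5-fold lower number from compound 2 to compound 3 (0.54 log units; beyond the scatter). Compound 4 differs from compound 3 by methyl in place of chloro on an aromatic carbon; this is the same change as that from compound 2 to compound 1, made on the core of compound 3 instead, and it occurs twice among these compounds.

Within the data shown here, the expectation for compound 4 rests on the single earlier instance of this change, which produced a step inside the usual scatter, and on the value of compound 3, 840 nM, as the starting point. Compound 4 is therefore expected to land near compound 3, with an estimated step of a 1.4-fold lower number from compound 3 to compound 4 (0.15 log units; within the scatter) that mirrors the earlier one in direction but is not expected to be large. The estimate for compound 4 in this assay is 600 nM, with a likely range from 250 nM to 1400 nM; the earlier step being within scatter means a value essentially matching compound 3 would not surprise.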

Compound 4, half-maximal inhibitory concentration: 1600 nM
The estimate for compound 4 lay 2.7-fold (0.43 log units) below the measured number; measured number outside the range, above it.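

On the dimethylamino core, the change from 4-chlorobenzyl to 4-methylbenzyl gives a 1.9-fold higher number from compound 3 to compound 4 (0.28 log units; within the scatter), and in this assay this does not repeat what the same change did on the diethylamino core: the same change on two cores in this assay, a 1.9-fold lower number (0.29 log units; within the scatter) from compound 2 to compound 1 and a 1.9-fold higher number (0.28 log units; within the scatter) from compound 3 to compound 4, 3.7-fold (0.57 log units) apart, beyond the scatter of two such steps

Read along the other edge of the same four compounds, the change from diethylamino to dimethylamino, a step beyond the scatter on the chloro pair, comes to a 1.1-fold higher number from compound 1 to compound 4 (0.03 log units; within the scatter) on the methyl pair: the same change on two cores in this assay, a 3.5-fold lower number (0.54 log units; beyond the scatter) from compound 2 to compound 3 and a 1.1-fold higher number (0.03 log units; within the scatter) from compound 1 to compound 4, 3.7-fold (0.57 log units) apart, beyond the scatter of two such steps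

Each methyl-for-chloro step lies within the scatter when taken alone, and neither establishes a direction; only the gap between them lies beyond it, and that gap shows only that, in these four compounds, a step measured on one core was not a safe guide to the other, not why the two differ or that the same would hold on any further core.

The compounds shown leave open whether a fluoro or methoxy group on the benzyl arm would follow compound 3 and compound 4 or compound 2 and compound 1. They also leave open how the arm would read against a pyrrolidine or morpholine in place of the dimethylamino group, and what lies behind the gap remains unanswered.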